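Swapping the Amide Nitrogen Substituent: Methoxy to Methylpyrazolyl

The source may report more compounds than this note shows. Statements on the series, on what has been measured and on what is new or still open speak of the compounds shown alone.

Measured compounds:
Compound 1 `Cc1ccc(OCC(=O)N(Cc2cccs2)c2ncco2)cc1`: 0.3 nM
Compound 2 `CON(Cc1cccs1)C(=O)COc1ccc(C)cc1`: 10 nM

The two measured compounds share a core and differ only at the amide-type nitrogen. In an assay on HEK293 cells for agonist activity at transient receptor potential cation channel subfamily M member 8 (Homo sapiens), read by fluorescence and calcium flux, with a stated time of 15 min (on this read-out lower numbers stand for an effect already at smaller amounts and higher numbers for an effect only at larger amounts of compound), compound 1 gives 0.3 nM. Compound 2, in which methoxy stands in place of 1,3-oxazol-2-yl on that nitrogen, gives 10 nM in this assay and thus has the highest of the two numbers; its nearest neighbour is compound 1, and the step of a 33-fold higher number from compound 1 to compound 2 (1.52 log units; beyond the scatter) is large and beyond the scatter.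

Compound 3 `Cc1ccc(OCC(=O)N(Cc2cccs2)c2ccnn2C)cc1` is not yet measured. It differs from compound 2 in that (1-methyl-1H-pyrazol-5-yl in place of methoxy on an amide-type nitrogen). Going by the values given here, the one step that bears on this change is a 33-fold higher number from compound 1 to compound 2 (1.52 log units; beyond the scatter), where a five-membered aromatic ring with 2 hetero atoms on the same nitrogen was exchanged for methoxy and the number rose strongly. Compound 3 reverses the direction of that exchange with a related five-membered aromatic ring, so a large step to a lower number is expected, of roughly the size a 10-fold lower number from compound 2 to compound 3 (1.00 log units; beyond the scatter). Compound 3 is therefore estimated at 1 nM in this assay, within a range from 0.3 nM to 5 nM.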

Compound 3, half-maximal effective concentration: 422 nM
For compound 3 the middle estimate is 420-fold (2.63 log units) below the measured one; the whole stated range lies below it.
By their numbers in this assay, from the lowest: compound 1; then compound 2; then compound 3.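

In this assay, the result shows that a five-membered aromatic ring with 2 hetero atoms on the amide-type nitrogen does not in itself bring a low number: 1-methyl-1H-pyrazol-5-yl in place of methoxy gives a 42-fold higher number from compound 2 to compound 3 (1.63 log units; beyond the scatter), so this exchange runs in the same direction as the loss of the 1,3-oxazol-2-yl group. The exchange of one such ring for the other gives an even larger step, a 1400-fold higher number from compound 1 to compound 3 (3.15 log units; beyond the scatter), and methoxy, with no ring at all, falls between the two, so at this position the identity of the ring matters far more than the ring class shared by compound 1 and compound 3. Nothing given here bears on the reason for this wide gap between the two rings.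

The compounds shown leave open whether the higher number of compound 3 goes with the methyl on the 1-methyl-1H-pyrazol-5-yl group or with the ring itself. They also leave open where a 1,3-thiazol-2-yl or a phenyl group on the same nitrogen would fall among these three compounds.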